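The source may report more compounds than this note shows. Statements on the series, on what has been measured and on what is new or still open speak of the compounds shown alone.

Of the compounds shown here, three built on one shared core have been tested in an assay on Sf9 cells for inhibition of protein deacetylase HDAC6 (Homo sapiens), read by fluorescence, with stated times of 10 min and 2 h; a higher number here means a weaker inhibitor, a lower number a stronger inhibitor. Compound 1 `CCCCN(Cc1ccc(C(=O)NO)cc1)C(=O)NCCN1CCCC1` gives 74 nM in this assay. Compound 2 `CCCCN(Cc1ccc(C(=O)NO)cc1)C(=O)Nc1cc(C)ccn1` gives 43 nM in this assay, and the step of a 1.7-fold lower number from compound 1 to compound 2 (0.24 log units; within the scatter) stays within the scatter, so the two cannot be ranked. Compound 3 `CC(C)CN(Cc1ccc(C(=O)NO)cc1)C(=O)Nc1ccccc1` gives 12 nM in this assay, the lowest of the three numbers, and its steps to compound 2 and to compound 1 both lie beyond the scatter.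

Compound 4 `O=C(NO)c1ccc(CN(CCCCO)C(=O)Nc2ccccc2)cc1` has not yet been measured. It differs from compound 3 in a single place: 3-hydroxypropyl in place of isopropyl on a saturated chain carbon bound to an amide-type nitrogen. Among the measured compounds shown here, no measured step bears directly on this change. For the measured compounds named here, the only measured step, from compound 1 to compound 2, alters the group on the amide-type nitrogen and leaves the saturated chain untouched, and compound 3 is separated from compound 2 by more than one change, so no single comparison isolates the chain. The expected step of a 1.7-fold higher number from compound 3 to compound 4 (0.22 log units; within the scatter) is therefore set small, with a real chance of no change beyond the scatter. Compound 4 is estimated at 20 nM in this assay, with a range from 7 nM to 60 nM.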

Compound 4, half-maximal inhibitory concentration: 0.87 nM
Beside the measured number, compound 4's estimate is 23-fold (1.36 log units) above it, outside the stated range (below it).
By their numbers in this assay, from the lowest: compound 4; then compound 3; then compounds 2 and 1 (each within the scatter of the next).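

Among the compounds shown here, the change of isopropyl to 3-hydroxypropyl on a saturated chain carbon bound to an amide-type nitrogen gives a 14-fold lower number from compound 3 to compound 4 (1.14 log units; beyond the scatter) in this assay, the first measured evidence that this chain can strongly shift the number on its own, since no earlier step isolated it. For the compounds shown here, the step is also much larger than the only earlier single-place step, which changed the other group on the amide-type nitrogen, but this one change alters the chain's shape and adds an oxygen carrying a hydrogen-bond donor and acceptor, so it cannot show which of these differences counts. Nothing available explains the size of this step.

Still open, on these data alone, is whether the oxygen itself matters: a plain butyl chain in place of the 4-hydroxybutyl chain of compound 4 would test this, while a methoxy group, an amine or a carboxylic acid at the chain end, or a longer or shorter hydroxyalkyl chain, would show how specific the end group and its distance are. As far as these compounds go, it also remains open whether the same chain change would lower the number when the pyridinyl or pyrrolidinylethyl groups of the other compounds are present.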